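The source may report more compounds than this note shows. Statements on the series, on what has been measured and on what is new or still open speak of the compounds shown alone.

Four compounds here have the same atoms and bonds and differ only in their configuration as drawn. In an ADME assay on Akata cells (Homo sapiens) for cytotoxicity (a higher number here means that more compound is tolerated, a lower number that less compound is tolerated), compound 1 `Nc1nc2c(ncn2/C=C2\C[C@@H]2[C@@H](O)CO)c(=O)[nH]1` gives 61000 nM, compound 2 `Nc1nc2c(ncn2/C=C2/C[C@@H]2[C@@H](O)CO)c(=O)[nH]1` gives 56000 nM and compound 3 `Nc1nc2c(ncn2/C=C2\C[C@H]2[C@@H](O)CO)c(=O)[nH]1` gives 75000 nM. These three values lie within the scatter of one another, so compound 3 stands level with the other two.

Compound 4 `Nc1nc2c(ncn2/C=C2/C[C@H]2[C@@H](O)CO)c(=O)[nH]1` has not yet been measured. Its difference from compound 3 is small: the two compounds have the same atoms and bonds and differ only in configuration as drawn: 1 of 3 stereo elements differ; a double bond is drawn E in compound 3 and Z in compound 4. Among the measured compounds shown here, the closest precedent is the same double-bond change made with the saturated ring carbon in its other configuration, which gave a 1.1-fold lower number from compound 1 to compound 2 (0.04 log units; within the scatter). Changing that ring stereocentre alone gave a 1.2-fold higher number from compound 1 to compound 3 (0.09 log units; within the scatter), and changing both elements together gave a 1.3-fold higher number from compound 2 to compound 3 (0.13 log units; within the scatter). All three steps stay within the scatter, so neither element has yet shown a measurable effect on how much compound the cells tolerate. For this reason, no step beyond the scatter is expected in this assay, and any direction can only be tentative. The expected change is a 1.2-fold lower number from compound 3 to compound 4 (0.06 log units; within the scatter), which would be too small to tell apart from repeat measurements. The estimate for compound 4 is 65000 nM, with an expected range from 38000 nM to 110000 nM.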

Compound 4, half-maximal cytotoxic concentration: 78000 nM
For compound 4 the middle estimate is 1.2-fold (0.08 log units) below the measured one, within the range that was stated.
By their numbers in this assay, from the lowest: compounds 2, 1, 3 and 4 (each within the scatter of the next).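

In this assay the double-bond change can now be read with the saturated ring carbon in either configuration: a 1.0-fold higher number from compound 3 to compound 4 (0.02 log units; within the scatter) stands alongside the earlier 1.1-fold lower number from compound 1 to compound 2 (0.04 log units; within the scatter) and both lie within the scatter. The ring stereocentre can likewise be read with the double bond in either form, as a 1.4-fold higher number from compound 2 to compound 4 (0.14 log units; within the scatter) joins the earlier 1.2-fold higher number from compound 1 to compound 3 (0.09 log units; within the scatter) and again neither step leaves the scatter. Even with both elements changed together, a 1.3-fold higher number from compound 1 to compound 4 (0.11 log units; within the scatter) and this also stays within the scatter, so all four combinations of these two elements now stand level, whereas the earlier compounds left one combination unread.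

Going by these compounds, the third stereo element is drawn the same way in all four compounds, so whether it matters for how much compound these cells tolerate remains open. Also open, on these data alone, is whether this indifference to configuration would hold for compounds carrying a different group on the shared core, such as a carboxylic acid, an amine or a longer chain.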